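Hydrogen in place of trifluoromethyl: compound 1 to compound 4

This account rests on a few compounds, and the source may have more. Where it says the series, first, only, none or still open, it means among the compounds named here.

Of the compounds shown here, three have been read so far in a functional assay on A549 cells (Homo sapiens) for antiproliferative activity, read by MTT assay, with a stated time of 24 h; a higher number here means a weaker inhibitor, a lower number a stronger inhibitor. Compound 1 `C=CCc1cc(-c2cccc(C(F)(F)F)c2)ccc1O` gives 73000 nM, and compound 3 `C=CCc1cc(-c2ccc(OC)cc2)cc(CC=C)c1O` gives 75600 nM. These two numbers lie within the scatter of each other, so neither ranks ahead. Compound 2 `C=CCc1cc(-c2cc(F)cc(F)c2)ccc1O` returns only a limit, > 100000 nM. Compound 1 therefore shares the only numeric level in the set with compound 3.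

The next compound to read is compound 4 `C=CCc1cc(-c2ccccc2)ccc1O`. It differs from compound 1 by hydrogen in place of trifluoromethyl on an aromatic carbon, meta to a large group: hydrogen in place of trifluoromethyl on an aromatic carbon.

Going by the values given here, no measured pair isolates this change, so its size has no direct precedent. The expectation rests on the level of compound 1 at 73000 nM. It also rests on the limit seen for compound 2, which points to little room for a stronger number. In this assay, a small move toward a weaker number is expected, possibly none beyond the scatter. The expected step is a 1.2-fold higher number from compound 1 to compound 4 (0.07 log units; within the scatter). A limit instead of a number remains possible. The estimate for compound 4 is 85000 nM, with an expected range of 45000 nM to 130000 nM.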

Compound 4, half-maximal inhibitory concentration: > 100000 nM
Compound 4 gave a limit, no number (the forecaster's own chance of this, stated with the estimate: 30%); middle value at least 1.1-fold (0.07 log units) away from the limit.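

Going by these compounds alone, the first pair that differs in one place gives, in this assay, an at least 1.3-fold higher number from compound 1 to compound 4 (0.13 log units; that floor lies within the scatter), with hydrogen in place of trifluoromethyl on an aromatic carbon, meta to a large group. Compound 4 carries a limit and not a number, so only a floor is known for this step, and that floor alone does not separate the two compounds. The unsubstituted ring of compound 4 therefore gives no numeric level, and the series now holds two compounds that return no number: the limit of > 100000 nM in this assay, at which 2 of the 4 values shown sit.

Going by these compounds, whether trifluoromethyl at this place truly matters, beyond the scatter, stays open until a number replaces the limit for compound 4 or a stronger compound brackets the change. Also open, on these data alone, is the reading for a chlorine, an amine or a carboxylic acid on this same aromatic carbon, which would show whether a numeric level here is particular to trifluoromethyl or is shared by other groups.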